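From Methyl Ester to Ethyl Ester: an Expected Value

The compounds below may be only part of what the source reports. "The series", "measured", "known", "first", "only" and "open" are said of these compounds alone.

Compound 1, `COc1ccc2c(c1)OC(c1cc(OC)c(OC)c(OC)c1)C(C(=O)NC(C)(C)C)=C2`, in a functional assay for inhibition of nuclear factor NF-kappa-B complex (Homo sapiens) (on this read-out lower numbers stand for stronger inhibition and higher numbers for weaker inhibition), gives 28400 nM.
Compound 2, `COc1ccc2c(c1)OC(c1cc(OC)c(OC)c(OC)c1)C(C(=O)Nc1ccccc1)=C2`, in this assay gives 17500 nM.
Compound 3, `COC(=O)C1=Cc2ccc(OC)cc2OC1c1cc(OC)c(OC)c(OC)c1`, in this assay gives 13800 nM.

Among these three, compound 3 gives the lowest number, although its gap to compound 2 is within the scatter, so only its separation from compound 1 counts as real. All three share one core and differ only in the group carried on the carbonyl carbon.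

Compound 4, `CCOC(=O)C1=Cc2ccc(OC)cc2OC1c1cc(OC)c(OC)c(OC)c1`, has not yet been measured. It differs from compound 3 by methyl in place of hydrogen on a saturated chain carbon bound to an oxygen next to a carbonyl group. Among the measured compounds shown here, no measured step touches this exact spot; the closest are the two steps that replaced an amide nitrogen on the carbonyl carbon with a methoxy group: a 2.1-fold lower number from compound 1 to compound 3 (0.31 log units; beyond the scatter) and a 1.3-fold lower number from compound 2 to compound 3 (0.10 log units; within the scatter). Both were small, and the change from compound 3 to compound 4 is smaller still, adding a single carbon one bond further out. The expectation is therefore no step beyond the scatter, in either direction. The expected step is a 1.1-fold lower number from compound 3 to compound 4 (0.03 log units; within the scatter). Compound 4 is expected to give about 13000 nM, within a range from 6000 nM to 28000 nM.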

Compound 4, half-maximal inhibitory concentration: 25000 nM
For compound 4 the middle estimate is 1.9-fold (0.28 log units) below the measured one; the range from low to high includes it.
By their numbers in this assay, from the lowest: compounds 3, 2, 4 and 1 (each within the scatter of the next, the first and the last beyond it).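

In this assay, the change methoxy to ethoxy, with methyl in place of hydrogen on a saturated chain carbon bound to an oxygen next to a carbonyl group, gives a 1.8-fold higher number from compound 3 to compound 4 (0.26 log units; within the scatter), so this small addition does not register as a real change. Compound 4 also cannot be separated from either amide, with a 1.4-fold higher number from compound 2 to compound 4 (0.15 log units; within the scatter) and a 1.1-fold lower number from compound 1 to compound 4 (0.06 log units; within the scatter). This qualifies the earlier picture: methoxy on the carbonyl carbon in compound 3 was separated from the (tert-butyl)amino group of compound 1, but ethoxy in the same place shows no such separation, so having an ester there does not by itself set a compound apart from compound 1.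

Going by these compounds, whether a longer chain on the oxygen, such as propoxy or butoxy, or a carboxylic acid in place of the ester would give a step beyond the scatter remains open. Nothing available bears on what lies behind these numbers.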